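This account rests on a few compounds, and the source may have more. Where it says the series, first, only, none or still open, it means among the compounds named here.

Among the compounds with values here, in a toxicity assay on Vero cells (Chlorocebus sabaeus) for cytotoxicity (on this read-out higher numbers stand for lower toxicity in this test and lower numbers for higher toxicity in this test), compound 1 `COc1nc(C(C)(C)C)ccc1[C@@H](c1ccccc1)[C@@](O)(CCN(C)C)c1cccc2ccccc12` gives 27.6 ug/mL, the only actual number so far. Compound 2 `COc1nc(-c2cccc(Cl)c2)ccc1[C@@H](c1ccccc1)[C@@](O)(CCN(C)C)c1cccc2ccccc12` reads > 50 ug/mL, which is a limit of the assay and not a number. Compound 3 `COc1nc(-c2ccccc2F)ccc1[C@@H](c1ccccc1)[C@@](O)(CCN(C)C)c1cccc2ccccc12` departs from compound 1 at a single place: 2-fluorophenyl in place of tert-butyl on an aromatic carbon. There, 2-fluorophenyl stands in place of tert-butyl, on an aromatic carbon next to the ring nitrogen. Within the data shown here, the one measured step bearing on this is an at least 1.8-fold higher number from compound 1 to compound 2 (0.25 log units; that floor lies within the scatter), where 3-chlorophenyl replaces the same tert-butyl. Its floor lies within the scatter, so it offers only a weak hint of a higher number in this assay. The expected change is modest and upward, and the estimated step is a 1.5-fold higher number from compound 1 to compound 3 (0.18 log units; within the scatter), which stays within the scatter. Compound 3 is therefore estimated at 42 ug/mL, with an expected range from 21 ug/mL to 85 ug/mL.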

Compound 3, half-maximal cytotoxic concentration: > 50 ug/mL
Compound 3 ended at the assay's limit; the forecaster's own chance of this, stated with the estimate: 45%; middle value at least 1.1-fold (0.07 log units) away from the limit.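

At this place, on an aromatic carbon next to the ring nitrogen, a second substituted phenyl behaves as the first did in this assay: the change gives an at least 1.8-fold higher number from compound 1 to compound 3 (0.25 log units; that floor lies within the scatter). The weak hint from compound 2 thus recurs with 2-fluorophenyl in place of 3-chlorophenyl, although the floor of this step still lies within the scatter, so a real rise over compound 1 is not established. The step between compound 2 and compound 3 cannot be read, because both end at the same limit, which is not a number: the limit of > 50 ug/mL in this assay, at which 2 of the 3 values shown sit.

The compounds shown leave open where the true values of compound 2 and compound 3 lie, and whether the fluorine or the chlorine on the phenyl matters at all. They also leave open how an unsubstituted phenyl, an amine such as morpholine or a carboxylic acid would read at this place.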